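The source may hold more compounds than are shown below. What is called first, only, known or untested is meant among the compounds shown, and "the series" means these compounds.

Of the compounds shown here, three of a shared terpene-like core have been tested in a functional assay on LoVo cells (Homo sapiens) for antiproliferative activity; a higher number here means a weaker inhibitor, a lower number a stronger inhibitor. Compound 1 `C=C/C(C)=C\CC1[C@](C)(O)CC[C@H]2C(C)(C)CCC[C@]12C` gives 20.3 ug/mL in this assay. Compound 2 `C=C[C@@](C)(O)CCC1C(=C)CC[C@H]2[C@](C)(COC(=O)CCC(=O)O)CCC[C@]12C` reaches only a limit of the assay, > 25 ug/mL, so no number is known for it. Compound 3 `C=C[C@@](C)(O)CC[C@H]1C(=C)CC[C@H]2C(C)(C)CCC[C@]12C` also reaches only a limit in this assay, > 25 ug/mL. Compound 3 therefore stands at the limit, as the limit of > 25 ug/mL in this assay, at which 2 of the 3 values shown sit, shows, and its value in this assay cannot be placed above or below that of compound 2; only compound 1 gives an actual number, and nothing says whether compound 3 is weaker than compound 1 by more than the scatter.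

Compound 4 `C=C[C@@](C)(O)CC[C@H]1C(=C)CC[C@H]2[C@](C)(COC(=O)CCC(=O)OC)CCC[C@]12C` has not yet been measured in this assay. It differs from compound 3 in one place: ((2-(methoxycarbonyl)ethyl)carbonyl)oxy in place of hydrogen on a saturated chain carbon bound to a saturated ring carbon. The ((2-(methoxycarbonyl)ethyl)carbonyl)oxy group enters on a saturated chain carbon bound to a saturated ring carbon.

Among the measured compounds shown here, because compound 3 sits at the limit, (the limit of > 25 ug/mL in this assay, at which 2 of the 3 values shown sit), no measured step exists to lean on, and the step from compound 3 to compound 4 is expected to be none beyond the scatter, a number no higher from compound 3 to compound 4 (the limit leaves the size open). Compound 4 is estimated at 25 ug/mL in this assay, within a range from 10 ug/mL to 60 ug/mL, with a real chance that only a limit is reported again.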

Compound 4, half-maximal inhibitory concentration: 10.6 ug/mL
The estimate for compound 4 lay 2.4-fold (0.37 log units) above the measured number; the measured number falls inside the stated range.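

Among the compounds shown here, putting ((2-(methoxycarbonyl)ethyl)carbonyl)oxy in place of hydrogen on a saturated chain carbon bound to a saturated ring carbon gives an at least 2.3-fold lower number from compound 3 to compound 4 (0.37 log units; beyond the scatter) in this assay, so a group at this place can go with a lower number, which the earlier compounds did not show. Compound 2, which also carries a chain at this place but ends in a carboxylic acid, gave only a limit, > 25 ug/mL. Compound 4 is thus the first compound with a group at this place to give an actual number, though the true size of its step remains unknown because compound 3 has no number of its own: the limit of > 25 ug/mL in this assay, at which 2 of the 4 values shown sit.

The compounds shown do not tell whether the whole chain of compound 4 is needed, or whether a shorter acetyloxy group in the same place would give a similar number. They also leave open what an amide or an amine at the end of the chain, or a longer chain carrying the same methyl ester, would give in this assay.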